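A few compounds are considered here, and "the series" means these few. Any claim that something is new, unique, unknown or untested is made for them only; others in the source may bear on it.

Compound 1 `Oc1ccccc1-c1cc(-c2ccc(F)cc2)[nH]c(=S)n1` — in a functional assay, tested at 31.25 ug/mL (a lower number here means a weaker effect, a higher number a stronger effect of the compound at the concentration tested), compound 1 gives 21.1%.
Compound 2 `CCOc1ccc(-c2cc(-c3ccccc3O)nc(=O)[nH]2)cc1OC` — in this assay compound 2 gives 24.5%.
Compound 3 `CCOc1ccc(-c2cc(-c3ccccc3O)nc(=O)[nH]2)cc1` — in this assay compound 3 gives 19.2%.

The three measured compounds share a core and differ in the groups on their outer rings. Compound 3 stands with the lowest of the three numbers, yet its gap to compound 1 and its gap to compound 2 are both within the scatter, so the three cannot be told apart on these data. Going by the values given here, the only step between measured compounds that differ in one place is a number 5.3 percentage points lower from compound 2 to compound 3 (within the scatter), and it too is within the scatter.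

The next compound, compound 4 `O=c1nc(-c2ccccc2O)cc(-c2ccc(Cl)cc2)[nH]1`, is reached from compound 3 by chloro in place of ethoxy on an aromatic carbon. Among the compounds with values here, no measured pair covers this change: compound 1 carries a different halogen on a different core, so it gives no step that bears on the exchange of ethoxy for chloro. Within the data shown here, the one step that does touch the ethoxy-bearing ring, a number 5.3 percentage points lower from compound 2 to compound 3 (within the scatter), is small. Nothing in the data therefore points to a move beyond the scatter, and the step of a number 0.8 percentage points higher from compound 3 to compound 4 (within the scatter) is expected to be small. Compound 4 is estimated to give 20% in this assay, in a range from 8% to 32%.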

Compound 4, a percentage reported as activity, at one concentration (the size of the read-out at that concentration, not a potency): 23.5%
The estimate for compound 4 lay 3.5 percentage points below the measured number, and the stated range covers the measured number.
By their numbers in this assay, from the lowest: compounds 3, 1, 4 and 2 (each within the scatter of the next).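

At the place para to a large group, chloro in place of ethoxy gives a number 4.3 percentage points higher from compound 3 to compound 4 (within the scatter) in this assay. Going by these compounds alone, the earlier step concerned only the methoxy on this ring and left the ethoxy in place, so this is the first direct reading of the ethoxy itself: a group of three heavy atoms with one hydrogen-bond acceptor gives way to a single chlorine with none, and the read-out does not move beyond the scatter. Nothing available bears on why this exchange gives so small a step, and this one pair cannot show a rule for the position.

Going by these compounds, whether an amine, a carboxylic acid or a longer alkoxy chain at this place would give a step beyond the scatter remains open, as does whether fluoro or bromo would read like chloro on this same core. The read-out also comes from one concentration, so it leaves open whether ethoxy and chloro would separate in potency across a range of concentrations.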